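Compound 3 to compound 4: fluoro in place of chloro

A few compounds are considered here, and "the series" means these few. Any claim that something is new, unique, unknown or untested is made for them only; others in the source may bear on it.

Compound 3 `Nc1c(C2=NCCCN2)cnn1-c1ccc(Cl)cc1` gives > 500000 nM in an ADME assay on Vero cells (Chlorocebus sabaeus) for cytotoxicity, read by CellTiter-Glo and ATP content, with a stated time of 72 h (on this read-out lower numbers stand for higher toxicity in this test and higher numbers for lower toxicity in this test), as a limit of the assay, not a number. Compound 2 `Nc1c(C2=NCCCN2)cnn1-c1ccccc1` gives > 500000 nM as a limit too. Compound 1 `Nc1c(C2=NCCN2)cnn1-c1ccc(F)cc1` also carries fluoro and gives > 500000 nM as a limit as well. The data so far rest on the limit of > 500000 nM in this assay, at which 3 of the 3 values shown sit, and on nothing finer. Compound 4 `Nc1c(C2=NCCCN2)cnn1-c1ccc(F)cc1` differs from compound 3 by fluoro in place of chloro on an aromatic carbon as fluoro in place of chloro on an aromatic carbon. Among the measured compounds shown here, the only measured step is a step that the two limits leave unreadable from compound 2 to compound 3 and it is chloro in place of hydrogen on an aromatic carbon. For the measured compounds named here, with that step as the sole guide, no step beyond the scatter is expected in this assay for this exchange. The expected change is a number no higher from compound 3 to compound 4 (the limit leaves the size open) and no more. Compound 4 is estimated at 500000 nM with an expected range of 250000 nM to 1000000 nM and will probably be reported only as a limit.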

Compound 4, half-maximal cytotoxic concentration: > 500000 nM
Compound 4 ended at the assay's limit (the forecaster's own chance of this, stated with the estimate: 90%); the middle value sits exactly at the limit.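

In this assay, the steps from compound 1, compound 2 and compound 3 to compound 4 cannot be read, as all four compounds rest on one limit of the assay: the limit of > 500000 nM in this assay, at which 4 of the 4 values shown sit.

Going by these compounds, how far each compound lies past that limit stays open, and so does whether hydrogen, chloro, fluoro or the six-membered non-aromatic ring changes this read-out at all.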